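Non-cytotoxic ester series: pyrrolidinyl replacement of cyclohexyl ester

The source may report more compounds than this note shows. Statements on the series, on what has been measured and on what is new or still open speak of the compounds shown alone.

Measured compounds:
Compound 1 `COC(=O)c1ccc(NCc2cncn2Cc2cccc(Cl)c2)cc1-c1ccccc1` — in a toxicity assay on NIH3T3 cells (Mus musculus) for cytotoxicity, read by resazurin assay (a lower number here means that less compound is needed, a higher number that more compound is needed for the effect), compound 1 gives > 10000 nM, a limit of the assay.
Compound 2 `O=C(OC1CCCCC1)c1ccc(NCc2cncn2Cc2ccc(-c3ccccc3)cc2)cc1-c1ccccc1` — in this assay compound 2 gives > 10000 nM, a limit of the assay.
Compound 3 `COC(=O)c1ccc(NCc2cncn2Cc2cccc([N+](=O)[O-])c2)cc1-c1ccccc1` — in this assay compound 3 gives > 10000 nM, a limit of the assay.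

Compound 2 therefore stands only at a limit in this assay; no number is known for it, and the same holds for the two other compounds, all three sitting at the limit of > 10000 nM in this assay, at which 3 of the 3 values shown sit. Going by the values given here, the one single-point step that has been measured, a step that the two limits leave unreadable from compound 1 to compound 3, is not readable in size because both ends are limits, so it gives no guide to how far any change can move the read-out.

Compound 4 `c1ccc(-c2ccc(Cn3cncc3CNc3ccc(N4CCCC4)c(-c4ccccc4)c3)cc2)cc1` differs from compound 2 by pyrrolidin-1-yl in place of cyclohexyloxycarbonyl on an aromatic carbon. Among the compounds with values here, no measured step bears on this change, and the only evidence available is that every compound so far sits at the limit. The expectation for compound 4 is therefore no step beyond the scatter, a step that the limit leaves unreadable from compound 2 to compound 4, with the likely outcome again a limit rather than a number. The estimate for compound 4 in this assay is 15000 nM, within 5000 nM to 50000 nM.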

Compound 4, half-maximal effective concentration: > 1000 nM
Compound 4: only a limit was reported (the forecaster's own chance of this, stated with the estimate: 70%); the middle value is on the limit's open side.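

In this assay compound 4 gives > 1000 nM, a limit of the assay. Compound 2 gives > 10000 nM, also a limit, and the step between compound 2 and compound 4 cannot be read. The compounds shown leave open whether pyrrolidin-1-yl in place of cyclohexyloxycarbonyl moves the read-out at all, and where any actual number for this series lies.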